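A few compounds are considered here, and "the series" means these few. Any claim that something is new, unique, unknown or untested is made for them only; others in the source may bear on it.

Compound 2 `CCOc1ccc(-c2cc(N)c(C(=O)c3cc(OC)c(OC)c(OC)c3)s2)cc1` gives 510 nM in a functional assay on FM3A cells (Mus musculus) for antiproliferative activity (on this read-out lower numbers stand for stronger inhibition and higher numbers for weaker inhibition), the highest of the three numbers recorded there; its nearest neighbour is compound 1 `COc1cc(C(=O)c2sc(-c3ccc(Cl)c(Cl)c3)cc2N)cc(OC)c1OC`, which gives 400 nM, and its furthest is compound 3 `COc1cc(C(=O)c2sc(-c3ccc([N+](=O)[O-])cc3)cc2N)cc(OC)c1OC`, which gives 64 nM. Compound 4 `COc1ccc(-c2cc(N)c(C(=O)c3cc(OC)c(OC)c(OC)c3)s2)cc1OC` carries the change (3,4-dimethoxyphenyl in place of 4-ethoxyphenyl on an aromatic carbon). Of the recorded steps, a 1.3-fold higher number from compound 1 to compound 2 (0.11 log units; within the scatter) shows that swapping one aryl group for another can leave the number where it was, while an 8.0-fold lower number from compound 2 to compound 3 (0.90 log units; beyond the scatter) and a 6.3-fold lower number from compound 1 to compound 3 (0.80 log units; beyond the scatter) show modest gains, both from the nitro group, which compound 4 does not carry. The step to compound 4 is therefore expected to be a 1.1-fold lower number from compound 2 to compound 4 (0.05 log units; within the scatter), with nothing beyond the scatter. Compound 4 is estimated at 450 nM, within 200 nM to 1000 nM.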

Compound 4, half-maximal inhibitory concentration: 72 nM
For compound 4 the middle estimate is 6.3-fold (0.80 log units) above the measured one; measured number outside the range, below it.
By their numbers in this assay, from the lowest: compounds 3 and 4 (each within the scatter of the next); then compounds 1 and 2 (each within the scatter of the next).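

In this assay, the 3,4-dimethoxyphenyl group next to the ring sulfur stands level with the 4-nitrophenyl group (a 1.1-fold higher number from compound 3 to compound 4 (0.05 log units; within the scatter)), so a nitro group is not required for a low number at this position. It also separates from both other aryl groups (a 7.1-fold lower number from compound 2 to compound 4 (0.85 log units; beyond the scatter); a 5.6-fold lower number from compound 1 to compound 4 (0.74 log units; beyond the scatter)), which shows that two aryl groups carrying oxygen can differ beyond the scatter here. Nothing available explains this difference. The compounds shown leave open whether the second oxygen or the shorter chain accounts for the step, which a 4-methoxyphenyl group would help separate. From the compounds shown here alone, how an aminophenyl group would behave at this position also stays open.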